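Swapping butyl for a difluoro branch on compound 3

A few compounds are considered here, and "the series" means these few. Any claim that something is new, unique, unknown or untested is made for them only; others in the source may bear on it.

In a functional assay on CHO cells with sphingosine 1-phosphate receptor 4 (Homo sapiens) as the target, read by GTPgammaS binding (on this read-out lower numbers stand for an effect already at smaller amounts and higher numbers for an effect only at larger amounts of compound), the three measured compounds all sit at the assay limit. Compound 1 `Cc1cc(CCC(=O)O)ccc1-c1noc(-c2ccc(OC(C)C)c(Cl)c2)n1` gives > 10000 nM, which is a limit and not a number. Compound 2 `Cc1cc(CCC(=O)O)ccc1-c1noc(-c2ccc(OC(C(F)(F)F)C(F)(F)F)c(C#N)c2)n1` gives > 10000 nM, again a limit. Compound 3 `CCCCc1ccc(-c2nc(-c3ccc(CCC(=O)O)cc3C)no2)nc1` gives > 10000 nM, likewise a limit; on the values shown, compound 3 therefore stands nowhere above or below its companions, since the limit of > 10000 nM in this assay, at which 3 of the 3 values shown sit, and no measured value separates them.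

Compound 4 `Cc1cc(CCC(=O)O)ccc1-c1noc(-c2ccc(C(F)(F)C(C)C)cn2)n1` is the next compound. Its difference from compound 3 is 1,1-difluoro-2-methylpropyl in place of butyl on an aromatic carbon, two atoms from the ring nitrogen of a six-membered aromatic ring with one nitrogen and para to a large group. Within the data shown here, no pair of measured compounds shows what such a change does in this assay, so no step size is known from the data.

With every measured value resting at the limit, the expectation for compound 4 is that the step that the limit leaves unreadable from compound 3 to compound 4 stays within the usual scatter. Compound 4 is accordingly estimated at 15000 nM, with a range from 3000 nM to 60000 nM, most probably reported again only as a limit.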

Compound 4, half-maximal effective concentration: > 10000 nM
Compound 4 was reported as a limit; the forecaster's own chance of this, stated with the estimate: 80%; the middle value is on the limit's open side.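

In this assay compound 4 gives > 10000 nM, which is a limit and not a number. Among these compounds, since compound 3 also rests on a limit, no step between compound 3 and compound 4 can be read. The compounds shown leave open how any of them compares with the others, as all share one boundary: the limit of > 10000 nM in this assay, at which 4 of the 4 values shown sit.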